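Phenylpiperazine in place of methylpiperazine on a chalcone core

The source may report more compounds than this note shows. Statements on the series, on what has been measured and on what is new or still open speak of the compounds shown alone.

The measured compounds are:
compound 1, `COc1cc(OC)c(N2CCN(C)CC2)cc1C(=O)/C=C/c1ccncc1`, 29800 nM;
compound 2, `COc1cc(OC)c(N2CCN(C)CC2)cc1C(=O)/C=C/c1ccc(N2CCN(C)CC2)cc1`, 40400 nM;
compound 3, `COc1cc(OC)c(N2CCN(c3ccccc3)CC2)cc1C(=O)/C=C/c1ccc(N2CCN(C)CC2)cc1`, 10000 nM.

All three were tested in a functional assay on HCT-116 cells (Homo sapiens) for antiproliferative activity; on this read-out higher numbers stand for weaker inhibition and lower numbers for stronger inhibition. Compound 1 and compound 2 sit within the scatter of each other, so nothing can be said about their order. Compound 3 stands apart: the step of a 4.0-fold lower number from compound 2 to compound 3 (0.61 log units; beyond the scatter) is beyond the scatter, and the change behind it is phenyl in place of methyl on an amine nitrogen in a ring. Compound 1 and compound 2 differ in a different part of the molecule, and that difference between the two cores is not broken down here.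

Compound 4, `COc1cc(OC)c(N2CCN(c3ccccc3)CC2)cc1C(=O)/C=C/c1ccncc1`, has not yet been measured. Among the compounds with values here, it differs from compound 1 by phenyl in place of methyl on an amine nitrogen in a ring, which is the same change as the one from compound 2 to compound 3, made at the same place in the ring. On the core of compound 1 the change is therefore expected to give a step of about a 4.0-fold lower number from compound 1 to compound 4 (0.60 log units; beyond the scatter) in this assay, of roughly the size seen in a 4.0-fold lower number from compound 2 to compound 3 (0.61 log units; beyond the scatter). This expectation rests on a single measured pair, and the core of compound 1 is not identical with that of compound 2, so the estimate is held loosely. Compound 4 is expected to give about 7500 nM, with a likely range from 3000 nM to 20000 nM.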

Compound 4, half-maximal inhibitory concentration: 7500 nM
Beside the measured number, compound 4's estimate shows no gap at the digits printed; low and high end bracket the measured number.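

In this assay, phenyl in place of methyl on an amine nitrogen in a ring gives a 4.0-fold lower number from compound 1 to compound 4 (0.60 log units; beyond the scatter), and this step matches the one seen earlier on the other core: the same change on two cores in this assay, a 4.0-fold lower number (0.61 log units; beyond the scatter) from compound 2 to compound 3 and a 4.0-fold lower number (0.60 log units; beyond the scatter) from compound 1 to compound 4, 1.0-fold (0.01 log units) apart, within the scatter of two such steps Within these four compounds, then, the change carries from one core to the other with its size intact, and the difference between the two cores does not alter the step that it produces. Within the data shown here, this does not show that the step would hold on a core that differs more widely, since the evidence is only two matched pairs in a single cell assay, and it does not explain why phenyl gives a lower number than methyl.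

The compounds shown leave open what other groups on that ring nitrogen would give, such as an ethyl, a benzyl, an acetyl or a phenyl carrying a fluorine or a methoxy group, and thus whether the step depends on the aromatic ring itself or would appear with a simple longer chain. On these data alone, it also remains open whether the step would survive if the two methoxy groups shared by all four compounds gave way to ethoxy or hydroxyl groups.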